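The source may hold more compounds than are shown below. What is called first, only, known or untested is meant among the compounds shown, and "the series" means these compounds.

Values measured in a physicochemical assay, with a stated time of 6 min (on this read-out higher numbers stand for weaker inhibition and lower numbers for stronger inhibition), are these
- compound 1 `O=C(Nc1cccc([N+](=O)[O-])c1)Nc1nc(-c2cc3cc(Br)ccc3o2)cs1` gives 159000 nM
- compound 2 `O=C(Nc1cccc(Cl)c1)Nc1nc(-c2cc3ccccc3o2)cs1` gives 14100 nM
- compound 3 `O=C(Nc1ccc(Cl)cc1)Nc1nc(-c2cc3cc([N+](=O)[O-])ccc3o2)cs1` gives 117000 nM

Compound 1 and compound 3 sit together at the high end of these numbers, within the scatter of each other, while compound 2 lies lower than compound 1 by a gap beyond the scatter. Compound 4 `O=C(Nc1ccccc1)Nc1nc(-c2cc3cc(Br)ccc3o2)cs1` has not yet been measured in this assay and follows from compound 1 by one change (hydrogen in place of nitro on an aromatic carbon) in which hydrogen replaces nitro on an aromatic carbon, turning 3-nitrophenyl into phenyl. Among the compounds with values here, no measured pair isolates this change, so its size can only be judged indirectly. The two nitro-bearing compounds sit at the high end, and compound 2 without nitro reads 14100 nM at the low end, but compound 2 also differs from compound 1 elsewhere, and three compounds make a thin basis. A moderate move toward lower numbers is therefore expected, with no return all the way to compound 2 assumed. The expected change is a 2.7-fold lower number from compound 1 to compound 4 (0.42 log units; beyond the scatter) and it may prove to lie close to the scatter. For compound 4 the estimated value is 60000 nM with an expected range from 15000 nM to 200000 nM at this stage.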

Compound 4, half-maximal inhibitory concentration: > 200000 nM
Compound 4 was reported as a limit; the forecaster's own chance of this, stated with the estimate: 10%; at least 3.3-fold (0.52 log units) between middle value and limit.
By their numbers in this assay, from the lowest: compound 2; then compounds 3 and 1 (each within the scatter of the next). At a limit, above all of these: compound 4.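

In this assay, compound 4 is reported only as a limit, > 200000 nM. The pair isolates hydrogen in place of nitro on an aromatic carbon, the change from 3-nitrophenyl to phenyl, with the rest of the structure unchanged, and it reads as an at least 1.2-fold higher number from compound 1 to compound 4 (0.09 log units; that floor lies within the scatter). This shows no move toward lower numbers at this position on this core, although the floor of the step lies within the scatter, and the size of any rise stays unknown, since the reading ends at a limit: the limit of > 200000 nM in this assay, at which 1 of the 4 values shown sits.

The compounds shown leave open whether an amine or a carboxylic acid in place of the nitro on this six-membered ring would give a lower number than the nitro compound or the unsubstituted phenyl. Within the data shown here, they also leave open whether the same change from 3-nitrophenyl to phenyl would read the same way on a core without the bromine, as no measured pair tests it there.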